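The source may hold more compounds than are shown below. What is called first, only, known or untested is meant among the compounds shown, and "the series" means these compounds.

Going by the values given here, compound 3 `CC(C)(F)c1ncncc1CNc1cc(N[C@H]2CC[C@@H](O)CC2)c(C#N)cn1` gives 32 nM in an assay on isolated protein for inhibition of protein kinase C theta type (Homo sapiens), read by TR-FRET, with a stated time of 2 h (a lower number here means a stronger inhibitor, a higher number a weaker inhibitor), the lowest of the three numbers measured so far. Compound 1 `N#Cc1cnc(NCc2cnccc2C(F)(F)F)cc1NC[C@H]1CC[C@@H](O)CC1` stands nearest with 58 nM, a gap that lies within the usual scatter, while compound 2 `N#Cc1cnc(NCc2cncnc2C(F)(F)F)cc1N[C@H]1CC[C@@H](O)CC1` stands furthest with 450 nM. Compound 4 `N#Cc1cnc(NCc2cncnc2-c2ccccc2)cc1N[C@H]1CC[C@@H](O)CC1` has not yet been measured; it differs from compound 3 by phenyl in place of 1-fluoro-1-methylethyl on an aromatic carbon. Among the compounds with values here, only one measured step bears on this aromatic carbon: a 14-fold lower number from compound 2 to compound 3 (1.15 log units; beyond the scatter). That step exchanged one small fluorinated group for another, and no measured pair places a phenyl on this aromatic carbon, so the direction of the present step cannot be read directly from a shown step. Within the data shown here, the one step does show that exchanging the group on this aromatic carbon can move the number beyond the scatter, so a change of that size is possible here in either direction. Weighing this, a moderate weakening is expected, a 3.1-fold higher number from compound 3 to compound 4 (0.49 log units; beyond the scatter), with wide uncertainty attached. Compound 4 is therefore estimated at 100 nM in this assay, within a range from 25 nM to 400 nM.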

Compound 4, half-maximal inhibitory concentration: 90 nM
Beside the measured number, compound 4's estimate is 1.1-fold (0.05 log units) above it, within the range that was stated.
By their numbers in this assay, from the lowest: compounds 3, 1 and 4 (each within the scatter of the next, the first and the last beyond it); then compound 2.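

In this assay, a six-membered aromatic ring of carbon only can stand on this aromatic carbon, which until now had carried only small fluorinated groups: the phenyl gives a 2.8-fold higher number from compound 3 to compound 4 (0.45 log units; beyond the scatter), yet also a 5.0-fold lower number from compound 2 to compound 4 (0.70 log units; beyond the scatter). The three groups at this place therefore fall into an order in which each step lies beyond the scatter, with 1-fluoro-1-methylethyl giving the lowest number, phenyl the middle one and trifluoromethyl the highest, so among these three compounds fluorine on the group is not required for the lower numbers, and the largest group does not give the highest number. Nothing given here accounts for this order or says why phenyl falls between the two fluorinated groups.

From the compounds shown here alone, three groups fix no trend, so it stays open whether a phenyl bearing a methoxy group or a chlorine, a pyridyl ring, or a saturated ring such as cyclopropyl or cyclohexyl would fall below or above the phenyl at this place. Also open, going by these compounds, is how an amine or a carboxylic acid on this carbon would fare, and whether the order of the three groups would hold with the other side chain of compound 1.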